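The source may hold more compounds than are shown below. What is called first, only, known or untested is meant among the compounds shown, and "the series" means these compounds.

Measured compounds:
compound 1 `COc1cccc2c1OCN(c1ccc3oc(-c4ccccc4)cc(=O)c3c1)C2`, 54%
compound 2 `O=c1cc(-c2ccccc2)oc2ccc(N3COc4c(Cl)cc(Cl)cc4C3)cc12`, 61.3%

In a functional assay on MCF7 cells (Homo sapiens) for inhibition, read by MTT assay, with a stated time of 48 h, tested at 15 ug/mL (on this read-out higher numbers stand for more inhibition of growth at the one concentration tested and lower numbers for less inhibition of growth), compound 1 gives 54%, the lower of the two numbers shown; the nearest, compound 2, gives 61.3%, a gap that lies within the scatter. Compound 3 `O=c1cc(-c2ccccc2)oc2ccc(N3COc4c(Br)cccc4C3)cc12` differs from compound 1 by bromo in place of methoxy on an aromatic carbon. Among the measured compounds shown here, no step between two measured compounds describes such a change, so there is no measured guide to its size. Compound 3 is expected to show no step beyond the scatter, a number 4 percentage points higher from compound 1 to compound 3 (within the scatter), with an estimate of 58% and a range from 40% to 75%.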

Compound 3, percent growth inhibition at one concentration: 37.8%
For compound 3 the middle estimate is 20.2 percentage points above the measured one; the whole stated range lies above it.
By their numbers in this assay, from the lowest: compound 3; then compounds 1 and 2 (each within the scatter of the next).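

In this assay, bromo in place of methoxy on an aromatic carbon ortho to a fused ring gives a number 16.2 percentage points lower from compound 1 to compound 3 (beyond the scatter), the first change among these compounds that can be read as a single swap. It shows that, for this pair, the number depends on which of these two groups the position carries. Nothing available here bears on why the number falls.

This single pair gives no trend for the position. Going by these compounds, whether an amine or a hydroxyl group on this carbon would give a number nearer that of compound 1 or compound 3 remains open.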